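A few compounds are considered here, and "the series" means these few. Any claim that something is new, unique, unknown or untested is made for them only; others in the source may bear on it.

For the measured compounds named here, compound 2, `COc1cc(-n2cnc3ccc(-c4ccc(C)cc4F)cc32)cc(OC)c1OC`, is the only compound with a numerical reading in a functional assay on MCF7 cells (Homo sapiens) for antiproliferative activity, read by MTT assay, with a stated time of 72 h; on this read-out higher numbers stand for weaker inhibition and lower numbers for stronger inhibition; in this assay compound 2 gives 56 nM. Compound 1, `COc1cc(-n2cnc3ccc(-c4ccccc4Cl)cc32)cc(OC)c1OC`, gives in this assay only a limit of the assay, > 10000 nM. Going by the values given here, the one measured step, an at least 170-fold lower number from compound 1 to compound 2 (2.25 log units; beyond the scatter), shows that changing the pendant aryl group on the shared core can move the reading very far, although one end of that step rests on the limit of > 10000 nM in this assay, at which 1 of the 2 values shown sits, and its true size is therefore unknown. Compound 3, `COc1cc(-n2cnc3ccc(-c4cccc([N+](=O)[O-])c4)cc32)cc(OC)c1OC`, is yet to be measured in this assay. It differs from compound 2 in one place: 3-nitrophenyl in place of 2-fluoro-4-methylphenyl on an aromatic carbon. The measured step bears on this one only in showing how much this position can matter; it gives no direction for 3-nitrophenyl. Compound 3 is expected to fall somewhat in potency, with an estimated step of a 7.1-fold higher number from compound 2 to compound 3 (0.85 log units; beyond the scatter). For compound 3 the estimated value is 400 nM, within a range of 60 nM to 5000 nM.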

Compound 3, half-maximal inhibitory concentration: 4560 nM
Estimate against measurement, compound 3: 11-fold (1.06 log units) below, and the stated range covers the measured number.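

In this assay, this position now shows a large change that does not rest on a limit: an 81-fold higher number from compound 2 to compound 3 (1.91 log units; beyond the scatter), so 3-nitrophenyl does not retain the reading given by 2-fluoro-4-methylphenyl. Compound 2 stands as the most potent of the three, with its steps to both others beyond the scatter, so a potent reading does not follow from simply having a substituted phenyl group here. The other new step, an at least 2.1-fold lower number from compound 1 to compound 3 (0.34 log units; beyond the scatter), places 3-nitrophenyl on the more potent side of 2-chlorophenyl, but its true size is unknown: the limit of > 10000 nM in this assay, at which 1 of the 3 values shown sits.

Going by these compounds, the three aryl groups differ in several features at once, so the separate contributions of the fluorine, the methyl and the nitro group remain open. Also open, on these data alone, is how an unsubstituted phenyl, or a phenyl carrying an amine or a carboxylic acid, would read in this assay.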